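Swapping acetamido for 4-carboxyphenyl: what to expect

The source may hold more compounds than are shown below. What is called first, only, known or untested is meant among the compounds shown, and "the series" means these compounds.

Compound 1 (`O=C1Nc2ccc(S(=O)(=O)N3CCOCC3)cc2/C1=N/c1cccc(C(F)(F)F)c1`): 14300 nM
Compound 2 (`CC(=O)N/N=C1\C(=O)Nc2ccc(S(=O)(=O)N3CCOCC3)cc21`): 27500 nM

In a functional assay on HepG2 cells (Homo sapiens) for cytotoxicity, read by sulforhodamine B assay, with a stated time of 24 h (on this read-out higher numbers stand for weaker inhibition and lower numbers for stronger inhibition), compound 2 gives 27500 nM and stands within the usual scatter of compound 1 (14300 nM). Compound 3 (`O=C1Nc2ccc(S(=O)(=O)N3CCOCC3)cc2/C1=N/c1ccc(C(=O)O)cc1`) carries 4-carboxyphenyl in place of acetamido on a double-bonded nitrogen. Among the compounds with values here, only one measured step bears on this change. It exchanges 3-(trifluoromethyl)phenyl and acetamido at that same place (a 1.9-fold higher number from compound 1 to compound 2 (0.28 log units; within the scatter)) and stays within the scatter. Within the data shown here, no compound with a 4-carboxyphenyl group has a measured value yet, so this guide is thin. With that single step as the basis, no change beyond the scatter is expected in this assay, and the estimated step is small (a 1.3-fold lower number from compound 2 to compound 3 (0.10 log units; within the scatter)). For compound 3 the expected value is 22000 nM (estimated range 9000 nM to 55000 nM).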

Compound 3, half-maximal inhibitory concentration: 23100 nM
Beside the measured number, compound 3's estimate is 1.1-fold (0.02 log units) below it, and the stated range covers the measured number.
By their numbers in this assay, from the lowest: compounds 1, 3 and 2 (each within the scatter of the next).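

In this assay, the new group on the double-bonded nitrogen gives a 1.2-fold lower number from compound 2 to compound 3 (0.08 log units; within the scatter), and set against the 3-(trifluoromethyl)phenyl group it gives a 1.6-fold higher number from compound 1 to compound 3 (0.21 log units; within the scatter). Within the data shown here, the single earlier step compared only two groups at this place, whereas three now lie within the usual scatter of one another: acetamido, 3-(trifluoromethyl)phenyl and 4-carboxyphenyl, a group that carries a carboxylic acid on its aromatic ring. No measurement at hand bears on what lies behind this result.

Still open, on these data alone, is whether an amine or a chain longer than acetamido at this place would give a step beyond the scatter. All three compounds also share one core, so the compounds shown say nothing about how a change elsewhere in it would read in this assay.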